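Swapping the ring substituent on the piperazine of compound 3

The source may report more compounds than this note shows. Statements on the series, on what has been measured and on what is new or still open speak of the compounds shown alone.

Three compounds share one core and differ only in the group on an amine nitrogen in a ring. Compound 1 `COc1ccc(N2CCN(C(=S)SCc3ccc(C(=O)Nc4ccccc4N)cc3)CC2)cc1` gives 25.3% in a functional assay on MGC-803 cells (Homo sapiens) for antiproliferative activity, read by CCK-8 assay, with a stated time of 72 h, tested at 2 uM; a lower number here means a weaker effect, a higher number a stronger effect of the compound at the concentration tested. Compound 2 `Cc1ccc(N2CCN(C(=S)SCc3ccc(C(=O)Nc4ccccc4N)cc3)CC2)cc1` gives 33.4%. Compound 3 `Nc1ccccc1NC(=O)c1ccc(CSC(=S)N2CCN(c3ccncc3)CC2)cc1` gives 64.8%, the highest of the three, and its lead over each of the other two is beyond the scatter.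

The two steps that reach compound 3 are large: a number 39.5 percentage points higher from compound 1 to compound 3 (beyond the scatter) and a number 31.4 percentage points higher from compound 2 to compound 3 (beyond the scatter), whereas a number 8.1 percentage points higher from compound 1 to compound 2 (within the scatter) stays within the scatter. Both large steps replace a six-membered carbon-only aromatic ring with pyridin-4-yl at this position.

Compound 4 `Nc1ccccc1NC(=O)c1ccc(CSC(=S)N2CCN(Cc3ccccc3)CC2)cc1` reverses that kind of change: benzyl in place of pyridin-4-yl on an amine nitrogen in a ring. Since a carbon-only ring at this position gave the lower numbers for compound 1 and compound 2, the expected step of a number 29.8 percentage points lower from compound 3 to compound 4 (beyond the scatter) is downward and beyond the scatter. Compound 4 is therefore estimated at 35% in this assay, with a range from 15% to 58%.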

Compound 4, a percentage reported as inhibition, at one concentration (the size of the read-out at that concentration, not a potency): 18.1%
Compound 4: the middle estimate sits 16.9 percentage points above what was measured; the measured number falls inside the stated range.
By their numbers in this assay, from the lowest: compounds 4, 1 and 2 (each within the scatter of the next, the first and the last beyond it); then compound 3.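

The change to benzyl on the amine nitrogen in the ring gives a number 46.7 percentage points lower from compound 3 to compound 4 (beyond the scatter) in this assay and extends the earlier finding to a carbon-only ring that has one more heavy atom than pyridin-4-yl. Replacing 4-methylphenyl with benzyl gives a number 15.3 percentage points lower from compound 2 to compound 4 (beyond the scatter) while replacing 4-methoxyphenyl with benzyl gives a number 7.2 percentage points lower from compound 1 to compound 4 (within the scatter) and so these carbon-only groups do not separate cleanly. No measured information here accounts for the large gap between pyridin-4-yl and benzyl.

Benzyl differs from pyridin-4-yl in both its ring atoms and its size, so pyridin-4-ylmethyl would help separate those two changes. A pyridin-3-yl group would show whether the place of the ring nitrogen matters.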